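This account rests on a few compounds, and the source may have more. Where it says the series, first, only, none or still open, it means among the compounds named here.

The measured compounds:

Compound 1, `C#CCSc1nc(Nc2ccc(C)cc2)c2ccncc2n1`: 6170 nM
Compound 2, `C#CCSc1nc(Nc2ccccc2Cl)c2ccncc2n1`: 17200 nM
Compound 3, `C#CCSc1nc(Nc2cccc(Cl)c2)c2ccncc2n1`: 1090 nM

These are values in a functional assay on HepG2 cells (Homo sapiens) for inhibition, read by MTT assay, with a stated time of 72 h; on this read-out higher numbers stand for weaker inhibition and lower numbers for stronger inhibition. Compound 3 has the lowest number of the three, with a 5.7-fold lower number from compound 1 to compound 3 (0.75 log units; beyond the scatter) and a 16-fold lower number from compound 2 to compound 3 (1.20 log units; beyond the scatter), both beyond the scatter. Compound 4, `C#CCSc1nc(Nc2ccc(Br)cc2)c2ccncc2n1`, differs from compound 3 by 4-bromophenyl in place of 3-chlorophenyl on a nitrogen on an aromatic ring. Among the measured compounds shown here, the step that bears most on this is the one between compound 1, which carries a 4-methylphenyl, and compound 3: a 5.7-fold lower number from compound 1 to compound 3 (0.75 log units; beyond the scatter). Bromine on the same position as that methyl is not measured here, so the size of the effect is uncertain, but a return toward the number of compound 1 seems plausible. Compound 4 is therefore expected to show a 3.2-fold higher number from compound 3 to compound 4 (0.51 log units; beyond the scatter), a higher number. The estimate for compound 4 in this assay is 3500 nM, with a range from 1200 nM to 10000 nM.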

Compound 4, half-maximal inhibitory concentration: 56200 nM
For compound 4 the middle estimate is 16-fold (1.21 log units) below the measured one; measured number outside the range, above it.
By their numbers in this assay, from the lowest: compound 3; then compound 1; then compound 2; then compound 4.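

A halogen on this phenyl ring does not by itself give a low number: 4-bromophenyl in place of 3-chlorophenyl gives a 52-fold higher number from compound 3 to compound 4 (1.71 log units; beyond the scatter), and in place of 2-chlorophenyl it gives a 3.3-fold higher number from compound 2 to compound 4 (0.51 log units; beyond the scatter). Bromo in place of methyl on the same aromatic carbon also raises the number, with a 9.1-fold higher number from compound 1 to compound 4 (0.96 log units; beyond the scatter), so the identity of this one group matters greatly. No available measurement explains the size of these steps. Still open, from the compounds shown here alone, is how an amine or a carboxylic acid on this phenyl ring would compare, and whether chloro and bromo differ on the same ring carbon.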